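Methyl in place of hydrogen: the step from compound 3 to compound 4

The source may hold more compounds than are shown below. What is called first, only, known or untested is meant among the compounds shown, and "the series" means these compounds.

Compound 1 `Cc1cccc(NC(=O)CN2CCC(c3cccc(F)c3)CC2)c1`: 40%
Compound 2 `Cc1cccc(NC(=O)CN2CCC(c3ccc(O)cc3)CC2)c1`: 60%
Compound 3 `Cc1cccc(NC(=O)CN2CCC(c3ccccc3)CC2)c1`: 37%

In a functional assay on HEK293 cells for agonist activity at D(4) dopamine receptor (Homo sapiens), read by FLIPR (on this read-out higher numbers stand for larger maximal responses and lower numbers for smaller maximal responses), compound 3 gives the lowest of the three numbers, although its gap to compound 1 lies within the scatter (a number 3 percentage points lower from compound 1 to compound 3 (within the scatter)), while compound 2 stands clearly apart (a number 23 percentage points lower from compound 2 to compound 3 (beyond the scatter)). Compound 4 `Cc1cccc(NC(=O)CN2CCC(c3ccccc3C)CC2)c1` differs from compound 3 by methyl in place of hydrogen on an aromatic carbon, ortho to a large group on the ring. Going by the values given here, no measured step swaps in a methyl; the one step that stays on this ring and does not involve hydroxy, a number 3 percentage points lower from compound 1 to compound 3 (within the scatter), is within the scatter, so only a small change, if any, is expected in this assay: a number 3 percentage points higher from compound 3 to compound 4 (within the scatter). Compound 4 is therefore estimated at 40%, between 25% and 55%.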

Compound 4, largest response reached (reported as efficacy), in percent of the reference or control that the assay uses: 43%
For compound 4 the middle estimate is 3 percentage points below the measured one; the range from low to high includes it.
By their numbers in this assay, from the lowest: compounds 3, 1 and 4 (each within the scatter of the next); then compound 2.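

Putting a methyl on this aromatic carbon, ortho to a large group, leaves the maximal response in this assay where it was (a number 6 percentage points higher from compound 3 to compound 4 (within the scatter)), and 2-methylphenyl also sits level with 3-fluorophenyl (a number 3 percentage points higher from compound 1 to compound 4 (within the scatter)). Only compound 2, the 4-hydroxyphenyl compound, stays apart (a number 17 percentage points lower from compound 2 to compound 4 (beyond the scatter)), so this methyl does not reach what its hydroxy gives. Nothing measured here explains these numbers. Open, on these data alone, is whether a larger group at this place, such as an amine, a carboxylic acid or a longer chain, would shift the response.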